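Trimming a methoxy to a hydroxy group on the shared core

The source may report more compounds than this note shows. Statements on the series, on what has been measured and on what is new or still open speak of the compounds shown alone.

Of the compounds shown here, three have been tested in a functional assay on the whole organism (strain A/J) for inhibition, with Mus musculus as the target, with stated times of 1 h and 18 h, at a dose of 100 umol/kg by the oral route; a higher number here means more inhibition at the dose given (going by the name of the read-out), a lower number less inhibition. Compound 1 `COc1ccc(/C=N/N(C)C(=O)c2ccccc2OC)cc1OC` gives 59%, compound 2 `COc1ccc(/C=N/N(C)C(=O)c2ccc(OC)c(OC)c2)cc1OC` gives 79%, and compound 3 `COc1ccc(C(=O)N(C)/N=C/c2ccc(OC)c(OC)c2)cc1` gives 62%, which places compound 3 second of the three, close to compound 1 and well under compound 2. The measured steps were a number 3 percentage points higher from compound 1 to compound 3 (within the scatter) and a number 17 percentage points lower from compound 2 to compound 3 (beyond the scatter). Compound 4 `COc1ccc(/C=N/N(C)C(=O)c2ccc(O)cc2)cc1OC` differs from compound 3 by hydrogen in place of methyl on an oxygen on an aromatic ring. Among the compounds with values here, neither measured step removes a methyl from an oxygen, so no step bears directly on it; the only step beyond the scatter, the loss of a methoxy group from compound 2 to compound 3, was modest. A small step is therefore expected, a number 7 percentage points lower from compound 3 to compound 4 (within the scatter), giving compound 4 an estimated 55%, between 35% and 75%.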

Compound 4, a percentage reported as inhibition, in the whole organism at one dose (the size of the read-out at that dose, not a potency): 61%
Compound 4: the middle estimate sits 6 percentage points below what was measured, within the range that was stated.
By their numbers in this assay, from the lowest: compounds 1, 4 and 3 (each within the scatter of the next); then compound 2.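

In this assay, the first change made at this oxygen, hydrogen for methyl, stays within the scatter (a number 1 percentage points lower from compound 3 to compound 4 (within the scatter)), so the 4-methoxyphenyl and 4-hydroxyphenyl groups cannot be told apart at this dose. The 4-hydroxyphenyl group also stays within the scatter of the 2-methoxyphenyl group (a number 2 percentage points higher from compound 1 to compound 4 (within the scatter)). No measurement here offers an explanation for these results. On these data alone, it remains open whether a longer chain on this oxygen would shift the inhibition, and whether an amine or a carboxylic acid in place of the hydroxy group would do so.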